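Opening a Ring in a Leukotriene Receptor Ligand

The source may report more compounds than this note shows. Statements on the series, on what has been measured and on what is new or still open speak of the compounds shown alone.

Of the compounds shown here, three with a shared core have been tested in an assay on membranes from lung (Cavia porcellus) for binding affinity to cysteinyl leukotriene receptor (Homo sapiens); a higher number here means a weaker inhibitor, a lower number a stronger inhibitor. Compound 1 `CC(CCC(=O)O)Cc1cccc(OCc2ccc3ccccc3n2)c1` gives 140 nM in this assay. Compound 2 `O=C(O)CC1CCC(c2ccc(OCc3ccc4ccccc4n3)cc2)C1` gives 22 nM. Compound 3 `CC(CCCc1nnn[nH]1)c1cccc(OCc2ccc3ccccc3n2)c1` gives 31 nM. Compound 2 shows the lowest number of the three, but its value and that of compound 3 lie within the usual scatter of each other, so these two cannot be separated. The number for compound 1, by contrast, sits clearly higher, beyond the scatter.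

Compound 4 `O=C(O)CCCCc1ccc(OCc2ccc3ccccc3n2)cc1` has not been measured yet. It differs from compound 2 in one place: 4-carboxybutyl in place of 3-(carboxymethyl)cyclopentyl on an aromatic carbon. Going by the values given here, no measured pair in this set isolates such a change, so there is no direct precedent to lean on. The expectation is a modest weakening, a step of a 2.7-fold higher number from compound 2 to compound 4 (0.44 log units; beyond the scatter), which would carry the value beyond the scatter. Compound 4 is therefore expected to give about 60 nM in this assay, with a likely range from 20 nM to 200 nM.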

Compound 4, inhibition constant: 110 nM
For compound 4 the middle estimate is 1.8-fold (0.26 log units) below the measured one; low and high end bracket the measured number.
By their numbers in this assay, from the lowest: compounds 2 and 3 (each within the scatter of the next); then compounds 4 and 1 (each within the scatter of the next).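

Putting the open 4-carboxybutyl chain in place of 3-(carboxymethyl)cyclopentyl on this aromatic carbon gives a 5.0-fold higher number from compound 2 to compound 4 (0.70 log units; beyond the scatter) in this assay, which shows that the number responds to a change at this position. The two groups have the same count of hydrogen-bond donors and acceptors and neither has a net charge, so those counts do not distinguish them, whereas the ring and the heavy-atom count do differ. Nothing available explains why the number rises with this change.

Losing the ring and changing the heavy-atom count happen together in this single step, so the compounds shown cannot separate the two. As far as these compounds go, it also remains open how a longer chain such as 5-carboxypentyl, or an amine in place of the carboxylic acid, would behave at this position.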